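Side-chain base swap in the bis(benzyloxy) lactone series

The compounds below may be only part of what the source reports. "The series", "measured", "known", "first", "only" and "open" are said of these compounds alone.

Measured so far:
compound 1 `Nc1ncn(CCC2(N)OC(=O)C(OCc3ccccc3)=C2OCc2ccccc2)c(=O)n1` — in a functional assay on MCF7 cells (Homo sapiens) for inhibition, read by MTT assay, with a stated time of 72 h (on this read-out lower numbers stand for stronger inhibition and higher numbers for weaker inhibition), compound 1 gives only a limit of the assay, > 100000 nM.
compound 2 `Nc1ccn(CCC2(N)OC(=O)C(OCc3ccccc3)=C2OCc2ccccc2)c(=O)n1` — in this assay compound 2 gives 32000 nM.

Going by the values given here, compound 2 holds the only actual number in the set; the other reading is a limit (the limit of > 100000 nM in this assay, at which 1 of the 2 values shown sits). Among the compounds with values here, the single measured step is an at least 3.1-fold lower number from compound 1 to compound 2 (0.49 log units; beyond the scatter).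

Compound 3 `NC1(CCn2c(=O)[nH]c(=O)[nH]c2=O)OC(=O)C(OCc2ccccc2)=C1OCc1ccccc1` is the next candidate; against compound 2 the change is a group of 9 heavy atoms (3 carbon, 3 nitrogen, 3 oxygen; one six-membered aromatic ring with 3 hetero atoms) in place of a group of 8 heavy atoms (4 carbon, 3 nitrogen, 1 oxygen; one six-membered aromatic ring with 2 hetero atoms), on a saturated chain carbon, two bonds along the chain from a saturated ring carbon. Within the data shown here, only the step from compound 1 to compound 2 bears on this, and it ran toward a lower number when a ring with 3 hetero atoms gave way to one with 2. Compound 3 goes back to a ring with 3 hetero atoms, with extra double bonds and a second donor. A move toward a higher number is therefore expected, possibly ending at a limit again. Compound 3 is estimated at 80000 nM, with a range of 20000 nM to 300000 nM. The expected step is a 2.5-fold higher number from compound 2 to compound 3 (0.40 log units; beyond the scatter).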

Compound 3, half-maximal inhibitory concentration: 84900 nM
Compound 3: middle estimate off by 1.1-fold (0.03 log units), on the low side, and the stated range covers the measured number.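

Both compounds with a ring of 3 hetero atoms now read higher than compound 2 in this assay, so at this place, on a saturated chain carbon, the ring with 2 hetero atoms gives the lowest number of the three: a 2.7-fold higher number from compound 2 to compound 3 (0.42 log units; beyond the scatter). The added double bonds outside aromatic rings and the second hydrogen-bond donor do not bring the number below that of compound 2. The other new step is an at least 1.1-fold lower number from compound 1 to compound 3 (0.07 log units; that floor lies within the scatter), so compound 1 and compound 3 cannot be put in order from these data, and compound 1 stands only as a limit: the limit of > 100000 nM in this assay, at which 1 of the 3 values shown sits.

As far as these compounds go, whether a simple amine or a carboxylic acid in place of the ring would read lower than compound 2 remains open. So does the outcome of a longer chain between the ring and the shared core.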